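A few compounds are considered here, and "the series" means these few. Any claim that something is new, unique, unknown or untested is made for them only; others in the source may bear on it.

Within the data shown here, compound 2 `O=S(=O)(NCCCNCc1cccc2ccccc12)c1cc(C(F)(F)F)cc(C(F)(F)F)c1` gives the higher of the two numbers so far in a functional assay on ASPC1 cells (Homo sapiens) for inhibition, read by MTT assay, with a stated time of 72 h (a lower number here means a stronger inhibitor of growth, a higher number a weaker inhibitor of growth), 21000 nM, while compound 1 `COc1ccc(CNCCCNS(=O)(=O)c2cc(C(F)(F)F)cc(C(F)(F)F)c2)cc1OC` gives 6400 nM. Among the measured compounds shown here, the only step that bears on the change is a 3.3-fold higher number from compound 1 to compound 2 (0.52 log units; beyond the scatter), which shows that swapping the group on the saturated chain carbon bound to the amine nitrogen can move the number by a modest amount. Compound 3 `O=S(=O)(NCCCNCc1cccc(Cl)c1)c1cc(C(F)(F)F)cc(C(F)(F)F)c1` carries 3-chlorophenyl in place of naphthalen-1-yl on a saturated chain carbon bound to an amine nitrogen. For the measured compounds named here, no measured step covers a 3-chlorophenyl, so the expected direction is uncertain; a modest decrease, a 2.1-fold lower number from compound 2 to compound 3 (0.32 log units; beyond the scatter), is estimated. Compound 3 is expected to give 10000 nM, in the range 3000 nM to 30000 nM.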

Compound 3, concentration for 50% growth inhibition: 5900 nM
Compound 3: middle estimate off by 1.7-fold (0.23 log units), on the high side; the measured number falls inside the stated range.
By their numbers in this assay, from the lowest: compounds 3 and 1 (each within the scatter of the next); then compound 2.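

Putting 3-chlorophenyl in place of naphthalen-1-yl gives a 3.6-fold lower number from compound 2 to compound 3 (0.55 log units; beyond the scatter) and so shows that the second aromatic ring is not needed for the lower number at this position. Against the 3,4-dimethoxyphenyl of the other compound, the same group gives a 1.1-fold lower number from compound 1 to compound 3 (0.04 log units; within the scatter) and so the two substituted single rings cannot be told apart here. Nothing measured explains why the numbers move. Still open, going by these compounds, is how an unsubstituted phenyl or a pyridine ring would compare at this position. A longer chain between the amine and the ring is also untested among these compounds.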